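A few compounds are considered here, and "the series" means these few. Any claim that something is new, unique, unknown or untested is made for them only; others in the source may bear on it.

Working notes on the series. One core is shared throughout and only the group on the aromatic nitrogen changes. Compound 1 `COc1ccc(-c2cc(=O)c3c(OC)cc(OC)cc3n2C)cc1` carries a methyl there. In a functional assay on HepG2 cells (Homo sapiens) for antiproliferative activity, with a stated time of 72 h (on this read-out lower numbers stand for an effect already at smaller amounts and higher numbers for an effect only at larger amounts of compound), compound 1 gives "not determined" (no result reported), so no number places it relative to the others; of the three entries shown, one is the limit of > 20000 nM in this assay, at which 1 of the 3 values shown sits, and only one is a number. Compound 2 `C=CCNC(=O)n1c(-c2ccc(OC)cc2)cc(=O)c2c(OC)cc(OC)cc21` carries an allylcarbamoyl group on that nitrogen. In this assay compound 2 gives > 20000 nM, which is a limit of the assay and not a number. Compound 3 `COc1ccc(-c2cc(=O)c3c(OC)cc(OC)cc3n2S(=O)(=O)c2ccc(Br)cc2)cc1` carries a (4-bromophenyl)sulfonyl group on the same nitrogen, and in this assay compound 3 gives 16300 nM. Going by the values given here, the only measured step is an at least 1.2-fold lower number from compound 2 to compound 3 (0.08 log units; that floor lies within the scatter). Compound 4 `COc1ccc(-c2cc(=O)c3c(OC)cc(OC)cc3n2S(=O)(=O)c2ccc(Br)s2)cc1` differs from compound 1 as follows: (5-bromothiophen-2-yl)sulfonyl in place of methyl on an aromatic nitrogen. Among the compounds with values here, no measured step covers the exchange of methyl for a sulfonyl group, and compound 1 offers no number to step from. The nearest measured neighbour is compound 3, whose (4-bromophenyl)sulfonyl group resembles the entering (5-bromothiophen-2-yl)sulfonyl; compound 3 gives 16300 nM. For compound 4 in this assay a number near 15000 nM is therefore expected, within 5000 nM to 40000 nM, with a real chance that only a limit is reported.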

Compound 4, half-maximal effective concentration: > 48200 nM
Compound 4: no number, only a limit; the forecaster's own chance of this, stated with the estimate: 35%; middle value at least 3.2-fold (0.50 log units) from the limit.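

With the sulfonyl group kept on the aromatic nitrogen, exchanging only the ring on the sulfur in this assay gives an at least 2.9-fold higher number from compound 3 to compound 4 (0.47 log units; beyond the scatter). Going by these compounds alone, this is the first step at this position that lies beyond the scatter, whereas the earlier step from the allylcarbamoyl group to the (4-bromophenyl)sulfonyl group did not get past it, and it shows that the read-out responds to the ring on the sulfonyl sulfur and not only to the group type on the nitrogen. Compound 4 has no number, only a limit of the assay: the limit of > 48200 nM in this assay, at which 1 of the 4 values shown sits.

The step from compound 2 to compound 4 joins two limits and cannot be read, and compound 1 has no result, leaving the exchange of methyl for any sulfonyl group unplaced on this read-out. Also open, as far as these compounds go, is whether the step follows the five-membered ring or the bromine, and how a plain phenylsulfonyl group without bromine, a methylsulfonyl group, or a sulfonyl ring carrying an amine or a carboxylic acid would read in this assay.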